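Ethoxy to propoxy: one added methyl

The source may hold more compounds than are shown below. What is called first, only, known or untested is meant among the compounds shown, and "the series" means these compounds.

Compound 1 `CCOC(=O)COc1cc2ccc(=O)oc2cc1OCC(=O)OCC` gives "not determined" (no result reported)
Compound 2 `CCOc1ccc2c(C)cc(=O)oc2c1` gives 80000 nM

In a functional assay (trachea, Rattus norvegicus, strain Wistar) (on this read-out higher numbers stand for an effect only at larger amounts of compound and lower numbers for an effect already at smaller amounts), compound 2 gives 80000 nM and stands alone, as compound 1 has no numerical result. With one number there is no ranking to read. Compound 3 `CCCOc1ccc2c(C)cc(=O)oc2c1` differs from compound 2 by methyl in place of hydrogen on a saturated chain carbon, two bonds along the chain from an oxygen on an aromatic ring and so turns ethoxy to propoxy. Within the data shown here, no measured pair shows a step of this kind, so nothing beyond the usual scatter is expected, and the estimated 1.3-fold lower number from compound 2 to compound 3 (0.12 log units; within the scatter) stays small. Compound 3 is expected at 60000 nM with 20000 nM to 180000 nM as the estimated range.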

Compound 3, half-maximal effective concentration: 267000 nM
Compound 3: middle estimate off by 4.5-fold (0.65 log units), on the low side; measured number outside the range, above it.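

In this assay the change from ethoxy to propoxy gives a 3.3-fold higher number from compound 2 to compound 3 (0.52 log units; beyond the scatter) and so shows that this chain responds to a single added methyl, with the larger chain needing more compound for its effect. Among these compounds, this is the first measured step at this position, and it is a single pair, not a trend. Nothing in the data shown explains the shift. On these data alone, whether a longer chain such as butoxy would move the number further remains open. So does the effect of a branched group such as isopropoxy, or of an amine at the chain end.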